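A few compounds are considered here, and "the series" means these few. Any claim that something is new, unique, unknown or untested is made for them only; others in the source may bear on it.

Compound 1 `OC[C@H]1O[C@@H](n2cnc3c(SCc4ccccc4Cl)ncnc32)[C@H](O)[C@@H]1O` stands highest of the two numbers obtained in an assay on isolated protein for inhibition of Equilibrative nucleoside transporter 1 (Homo sapiens) (on this read-out higher numbers stand for weaker inhibition and lower numbers for stronger inhibition), where compound 1 gives 117 nM. Its nearest neighbour, compound 2 `N#Cc1cccc(CSc2ncnc3c2ncn3[C@@H]2O[C@H](CO)[C@@H](O)[C@H]2O)c1`, gives 36.3 nM in this assay, a step of a 3.2-fold lower number from compound 1 to compound 2 (0.51 log units; beyond the scatter) that comes from putting 3-cyanophenyl in place of 2-chlorophenyl on a saturated chain carbon bound to a sulfur.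

Compound 3 `N#Cc1ccc(CSc2ncnc3c2ncn3[C@@H]2O[C@H](CO)[C@@H](O)[C@H]2O)cc1` is not yet measured. It differs from compound 1 by 4-cyanophenyl in place of 2-chlorophenyl on a saturated chain carbon bound to a sulfur. Among the compounds with values here, the only step that bears on this change is the one from compound 1 to compound 2, which replaced the same 2-chlorophenyl with a cyanophenyl and lowered the number by a modest, clearly resolved margin. Compound 3 is therefore expected to follow a similar direction, with a step of a 2.3-fold lower number from compound 1 to compound 3 (0.37 log units; beyond the scatter) in this assay, though a cyanophenyl of a different kind may not match that margin exactly. The estimate for compound 3 is 50 nM, expected between 18 nM and 140 nM.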

Compound 3, inhibition constant: 4.57 nM
Estimate against measurement, compound 3: 11-fold (1.04 log units) above; the measured number lies below the stated range.
By their numbers in this assay, from the lowest: compound 3; then compound 2; then compound 1.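

Replacing 2-chlorophenyl with 4-cyanophenyl on a saturated chain carbon bound to a sulfur gives a 26-fold lower number from compound 1 to compound 3 (1.41 log units; beyond the scatter) in this assay, so a cyanophenyl at this position can do much more than the first step showed. The gain depends on where the nitrile sits on the ring and not only on its presence: 4-cyanophenyl in place of 3-cyanophenyl gives a 7.9-fold lower number from compound 2 to compound 3 (0.90 log units; beyond the scatter) on its own. Nothing available explains this difference between the two cyanophenyl groups.

As far as these compounds go, compound 1 and compound 3 differ in both the group on the ring and its place, so it remains open how 4-chlorophenyl would read. Also open, from the compounds shown here alone, is how a carboxylic acid or an amine in place of the nitrile, or a longer chain in place of the saturated chain carbon, would read.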